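Methylsulfonyl on the benzamide ring of compound 3

The source may hold more compounds than are shown below. What is called first, only, known or untested is meant among the compounds shown, and "the series" means these compounds.

Measured so far:
compound 1 `O=C(Nc1ccc(Cl)c(-c2nnc3c(Cl)cccn23)c1)c1ccc(F)cc1Cl` in a functional assay on MDA-MB-468 cells (Homo sapiens) for antiproliferative activity, read by MTT assay, with a stated time of 72 h; a higher number here means a weaker inhibitor, a lower number a stronger inhibitor: > 100000 nM.
compound 2 `O=C(Nc1ccc(Cl)c(-c2nnc3c(Cl)cccn23)c1)c1cccnc1` in this assay: > 100000 nM.
compound 3 `O=C(Nc1ccc(Cl)c(-c2nnc3c(Cl)cccn23)c1)c1ccccc1` in this assay: > 100000 nM.

Compound 3 stands at a limit in this assay, not at a number. The same holds for the two other measured compounds, so that all three sit at the limit of > 100000 nM in this assay, at which 3 of the 3 values shown sit. The steps among them are all unreadable: a step that the two limits leave unreadable from compound 1 to compound 3, a step that the two limits leave unreadable from compound 2 to compound 3 and a step that the two limits leave unreadable from compound 1 to compound 2. Among the measured compounds shown here, they show only that exchanging the aroyl group of the amide has left every compound at the limit.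

Compound 4 `CS(=O)(=O)c1cccc(C(=O)Nc2ccc(Cl)c(-c3nnc4c(Cl)cccn34)c2)c1` differs from compound 3 by methylsulfonyl in place of hydrogen on an aromatic carbon. For the measured compounds named here, no measured step reports a change in this position, and the three steps that bear on the amide aryl group are all unreadable. The expected step is therefore a number no higher from compound 3 to compound 4 (the limit leaves the size open), with a limit again the most likely outcome. Compound 4 is estimated at 100000 nM, in the range 30000 nM to 300000 nM.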

Compound 4, half-maximal inhibitory concentration: > 100000 nM
Compound 4: only a limit was reported; the forecaster's own chance of this, stated with the estimate: 80%; the middle value sits exactly at the limit.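

Compound 4 also stands only at a limit, as do compound 1, compound 2 and compound 3, so none of the steps to compound 4 can be read: the limit of > 100000 nM in this assay, at which 4 of the 4 values shown sit.

The compounds shown leave open whether any aroyl group on this amide gives a measurable value.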